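Fluoro to chloro on compound 2

The compounds below may be only part of what the source reports. "The series", "measured", "known", "first", "only" and "open" are said of these compounds alone.

In an ADME assay on Vero cells (Chlorocebus sabaeus) for cytotoxicity, with a stated time of 5 days (on this read-out lower numbers stand for stronger inhibition and higher numbers for weaker inhibition), compound 2 (`COc1nc(F)nc2c1ncn2[C@H]1C[C@H](N=[N+]=[N-])[C@@H](CO)O1`) reports only a limit, > 100000 nM. Compound 1 (`CN(C)c1nc(N)nc2c1ncn2[C@H]1C[C@H](N=[N+]=[N-])[C@@H](CO)O1`) also reports only a limit, > 100000 nM. Compound 3 (`[N-]=[N+]=N[C@H]1C[C@H](n2cnc3c(Cl)nc(F)nc32)O[C@@H]1CO`) gives a true number, 21800 nM. Compound 4 (`COc1nc(Cl)nc2c1ncn2[C@H]1C[C@H](N=[N+]=[N-])[C@@H](CO)O1`) keeps the methoxy group of compound 2 and differs from it by chloro in place of fluoro on an aromatic carbon. Among the measured compounds shown here, the one measured step that brings in chloro is an at least 4.5-fold lower number from compound 2 to compound 3 (0.66 log units; beyond the scatter), and it removes methoxy rather than fluoro, so it is only a loose guide. A small move toward lower numbers is expected, estimated as an at least 1.2-fold lower number from compound 2 to compound 4 (0.09 log units; that floor lies within the scatter). For compound 4 the estimate is 80000 nM, with an expected range of 25000 nM to 100000 nM, and another limit would not surprise.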

Compound 4, half-maximal inhibitory concentration: > 100000 nM
Compound 4: no number, only a limit (the forecaster's own chance of this, stated with the estimate: 55%); middle value at least 1.2-fold (0.09 log units) from the limit.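

Compound 2 and compound 4 each report only a limit in this assay, so the step between them cannot be read: the limit of > 100000 nM in this assay, at which 3 of the 4 values shown sit.

As far as these compounds go, whether chloro in place of fluoro on an aromatic carbon changes the read-out at all stays open.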